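A few compounds are considered here, and "the series" means these few. Any claim that something is new, unique, unknown or untested is made for them only; others in the source may bear on it.

Measured so far:
compound 1 `CN(C)Cc1ccc(CCCN/C(N)=N/C(=O)CC(c2ccccc2)c2ccccc2)o1` gives 7.03 in a functional assay on Sf9 cells for antagonist activity at histamine H2 receptor (Homo sapiens), with stated times of 2 min and 20 min; a lower number here means a less potent compound, a higher number a more potent compound, by a factor of ten per unit of this negative logarithm;
compound 2 `CN(C)Cc1ccc(CCCN/C(N)=N/C(=O)CC(c2ccccc2)c2nccs2)o1` gives 6.13 in this assay;
compound 3 `N/C(=N\C(=O)CC(c1ccccc1)c1ccccc1)NCCCc1ncc[nH]1` gives 6.13 in this assay.

Compound 4 `N/C(=N\C(=O)CC(c1ccccc1)c1nccs1)NCCCc1ncc[nH]1` has not yet been measured. It differs from compound 3 by 1,3-thiazol-2-yl in place of phenyl on a saturated chain carbon bound to an aromatic carbon and a saturated chain carbon. The same change has been made once before, from compound 1 to compound 2, where it reads 1,3-thiazol-2-yl in place of phenyl on a saturated chain carbon bound to an aromatic carbon and a saturated chain carbon and gave a number 0.90 log units lower from compound 1 to compound 2 (beyond the scatter). The cores of compound 1 and compound 3 differ by 1H-imidazol-2-yl in place of 5-((dimethylamino)methyl)furan-2-yl on a saturated chain carbon, three bonds along the chain from an amine nitrogen, while the place of the change is described in identical words in both pairs, so this is the same change carried onto a different core. Because a number 0.90 log units lower from compound 1 to compound 2 (beyond the scatter) was a clear loss, a similar step is expected from compound 3 to compound 4, a number 0.83 log units lower from compound 3 to compound 4 (beyond the scatter), with some allowance for the core not repeating the step exactly. Compound 4 is therefore estimated at 5.3, expected to fall between 4.7 and 5.9.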

Compound 4, negative logarithm of the antagonist equilibrium constant: 5.19
Beside the measured number, compound 4's estimate is 0.11 log units above it; measured number inside the range.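

In this assay, putting 1,3-thiazol-2-yl in place of phenyl gives a number 0.94 log units lower from compound 3 to compound 4 (beyond the scatter), and this step matches the one on the other core: the same change on two cores in this assay, a number 0.90 log units lower (beyond the scatter) from compound 1 to compound 2 and a number 0.94 log units lower (beyond the scatter) from compound 3 to compound 4, 0.04 log units apart, within the scatter of two such steps Putting 1H-imidazol-2-yl in place of 5-((dimethylamino)methyl)furan-2-yl gives a number 0.94 log units lower from compound 2 to compound 4 (beyond the scatter), and this step likewise matches its earlier counterpart: the same change on two cores in this assay, a number 0.90 log units lower (beyond the scatter) from compound 1 to compound 3 and a number 0.94 log units lower (beyond the scatter) from compound 2 to compound 4, 0.04 log units apart, within the scatter of two such steps In these four compounds, each change therefore costs about the same whichever form the other part takes, but this does not show why either change lowers the number, nor that the match would hold on any further core.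

The compounds shown leave open how a pyridine ring or an amine would fare in place of phenyl, and what a longer chain would do to either core.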